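The source may report more compounds than this note shows. Statements on the series, on what has been measured and on what is new or still open speak of the compounds shown alone.

Compound 3 `O=C(CCCCOc1no[n+]([O-])c1S(=O)(=O)c1ccccc1)NO` carries the shared core with a chain ending in a hydroxycarbamoyl group, and in a functional assay on MDA cells (Homo sapiens) for inhibition, read by MTT assay, with a stated time of 48 h (on this read-out lower numbers stand for stronger inhibition and higher numbers for weaker inhibition), compound 3 gives 2530 nM. Its closest relative, compound 2 `O=C(CCCOc1no[n+]([O-])c1S(=O)(=O)c1ccccc1)NO`, has a shorter chain, and in this assay compound 2 gives 6200 nM. Among the compounds with values here, the one step between them, a 2.5-fold lower number from compound 2 to compound 3 (0.39 log units; beyond the scatter), is the only measured change in this set. A third relative, compound 1 `O=S(=O)(c1ccccc1)c1c(OCCCCCCO)no[n+]1[O-]`, in which the chain ends in a plain hydroxyl group, has in this assay only the entry "not determined" (no result reported), so no number stands for compound 1. On the numbers shown, compound 3 therefore holds the lowest value, with compound 2 clearly above it.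

Compound 4 `O=C(COCCOc1no[n+]([O-])c1S(=O)(=O)c1ccccc1)NO` differs from compound 3 in one place: (hydroxycarbamoyl)methoxy in place of 2-(hydroxycarbamoyl)ethyl on a saturated chain carbon, two bonds along the chain from an oxygen on an aromatic ring. Cut one bond further out, the same change reads 4-(hydroxycarbamoyl)butyl to 2-((hydroxycarbamoyl)methoxy)ethyl. Within the data shown here, no measured step tests this exchange directly; the only step at hand, a 2.5-fold lower number from compound 2 to compound 3 (0.39 log units; beyond the scatter), concerns chain length rather than this swap. The expected step is therefore small, a 1.4-fold higher number from compound 3 to compound 4 (0.14 log units; within the scatter), and compound 4 is estimated at 3500 nM, within 1500 nM to 8000 nM.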

Compound 4, half-maximal inhibitory concentration: 15100 nM
Compound 4: the middle estimate sits 4.3-fold (0.63 log units) below what was measured, and the stated range ends below it.
By their numbers in this assay, from the lowest: compound 3; then compound 2; then compound 4.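

In this assay the exchange of 2-(hydroxycarbamoyl)ethyl for (hydroxycarbamoyl)methoxy on this saturated chain carbon gives a 6.0-fold higher number from compound 3 to compound 4 (0.78 log units; beyond the scatter) and so is far from neutral, even though the two groups differ only in one carbon replaced by an oxygen. The same group also compares poorly with the (hydroxycarbamoyl)methyl of the shorter chain, with a 2.4-fold higher number from compound 2 to compound 4 (0.39 log units; beyond the scatter) on that exchange, so the lower number that came with the longer chain in compound 3 does not survive once the chain holds this oxygen. Nothing measured here gives a reason for this rise.

As far as these compounds go, whether an amine in place of the chain oxygen would behave like the oxygen or like the carbon remains open. So does whether a longer chain holding the same oxygen would recover the lower number of compound 3.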